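The compounds below may be only part of what the source reports. "The series", "measured", "known", "first", "only" and "open" are said of these compounds alone.

Working notes on the sulfamoylurea series.

Three compounds have numbers in an assay on liver for inhibition of sterol O-acyltransferase 1 (Rattus norvegicus), using microsomes; on this read-out higher numbers stand for weaker inhibition and lower numbers for stronger inhibition. Compound 1 `CCN(CC)S(=O)(=O)NC(=O)Nc1c(C(C)C)cccc1C(C)C` gives 2500 nM. Compound 2 `CCCCN(C)S(=O)(=O)NC(=O)Nc1c(C(C)C)cccc1C(C)C` gives 2300 nM. Compound 3 `CCCCCCNS(=O)(=O)NC(=O)Nc1c(C(C)C)cccc1C(C)C` gives 8100 nM, the highest of the three numbers. The step of a 1.1-fold lower number from compound 1 to compound 2 (0.04 log units; within the scatter) lies within the scatter, whereas a 3.2-fold higher number from compound 1 to compound 3 (0.51 log units; beyond the scatter) and a 3.5-fold higher number from compound 2 to compound 3 (0.55 log units; beyond the scatter) are modest steps beyond it, both on changing the group on the sulfonyl sulfur.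

Compound 4 `CCCCCCOS(=O)(=O)NC(=O)Nc1c(C(C)C)cccc1C(C)C` is not yet measured. It differs from compound 3 in one place: hexyloxy in place of hexylamino on a sulfonyl sulfur. The hexyl chain is unchanged; what changes is the atom joining it to the sulfonyl sulfur, a hydrogen-bond donor leaving and a hydrogen-bond acceptor entering.

Among the measured compounds shown here, none of the measured steps bears directly on this change. For the measured compounds named here, each of them swaps one amino group for another on the sulfonyl sulfur and keeps the nitrogen; no compound in the set carries an oxygen there. The measured steps only show that changes on this sulfonyl sulfur move this assay by modest amounts at most. The expected step of a 1.0-fold lower number from compound 3 to compound 4 (0.01 log units; within the scatter) is therefore not beyond the scatter, with a wide range to reflect the lack of a comparable step. Compound 4 is estimated at 8000 nM, within a range from 2500 nM to 25000 nM.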

Compound 4, half-maximal inhibitory concentration: 27000 nM
The estimate for compound 4 lay 3.4-fold (0.53 log units) below the measured number; measured number above the stated range.
By their numbers in this assay, from the lowest: compounds 2 and 1 (each within the scatter of the next); then compound 3; then compound 4.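

Holding the hexyl chain fixed and changing only the atom joining it to the sulfonyl sulfur gives, in this assay, a 3.3-fold higher number from compound 3 to compound 4 (0.52 log units; beyond the scatter) and shows that this joining atom matters in its own right, which steps that kept a nitrogen there could not show. Against the two compounds with disubstituted amino groups, hexyloxy gives a 12-fold higher number from compound 2 to compound 4 (1.07 log units; beyond the scatter) and an 11-fold higher number from compound 1 to compound 4 (1.03 log units; beyond the scatter), both large, so this position can move this assay further than the modest steps among the amino groups suggested, and compound 4 is the weakest inhibitor of the four. No measurement shown gives a reason for these steps, so the change in hydrogen-bond donors and acceptors remains a count and not an explanation.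

As far as these compounds go, whether oxygen in place of nitrogen costs as much on shorter chains remains open, for example with butyloxy or ethoxy set against butylamino or ethylamino. Also open, from the compounds shown here alone, is how a heptyl group, with a carbon joined directly to the sulfonyl sulfur, or a hexylthio group would compare with hexylamino and hexyloxy on the same core.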